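Adding a Phenyl Group Where Only a Limit Was Seen

A few compounds are considered here, and "the series" means these few. Any claim that something is new, unique, unknown or untested is made for them only; others in the source may bear on it.

Compound 1 `Cc1ccc(S(=O)(=O)N2CC[C@@H](Cl)C[C@@H]2CC(C)C)cc1`: in a functional assay on WiDr cells (Homo sapiens) for antiproliferative activity, read by sulforhodamine B assay, with a stated time of 48 h (a lower number here means a stronger inhibitor of growth, a higher number a weaker inhibitor of growth), compound 1 gives 22000 nM.
Compound 2 `Cc1ccc(S(=O)(=O)N2CC[C@@H](Cl)C[C@@H]2C2CCCCC2)cc1`: in this assay compound 2 gives 15000 nM.
Compound 3 `Cc1ccc(S(=O)(=O)N2CC=C(Cl)CC2)cc1`: in this assay compound 3 gives only a limit of the assay, not a number, > 100000 nM.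

Compound 3 therefore stands apart from the other two, sitting at the limit of > 100000 nM in this assay, at which 1 of the 3 values shown sits, where no growth inhibition could be measured. Compound 4 `Cc1ccc(S(=O)(=O)N2CCC(Cl)=CC2c2ccccc2)cc1` differs from compound 3 by phenyl in place of hydrogen on a saturated ring carbon. Among the compounds with values here, the only measured step, a 1.5-fold lower number from compound 1 to compound 2 (0.17 log units; within the scatter), swaps one group for another at that same kind of position and changed little. Compounds 1 and 2 both carry a large group there and both give measured numbers. Compound 3 carries hydrogen there and gives only a limit. Compound 4 is therefore expected to gain, a step of an at least 2.8-fold lower number from compound 3 to compound 4 (0.45 log units; beyond the scatter), though whether it reaches the range of compounds 1 and 2 is uncertain. The estimate for compound 4 is 35000 nM, with a range from 8000 nM to 150000 nM.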

Compound 4, concentration for 50% growth inhibition: 18000 nM
Compound 4: the middle estimate sits 1.9-fold (0.29 log units) above what was measured; the measured number falls inside the stated range.
By their numbers in this assay, from the lowest: compounds 2, 4 and 1 (each within the scatter of the next). At a limit, above all of these: compound 3.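

The earlier step only swapped one large group for another, so it said nothing about having a group at this position at all. Within the data shown here, replacing hydrogen with phenyl on this saturated ring carbon, next to the ring nitrogen, gives an at least 5.5-fold lower number from compound 3 to compound 4 (0.74 log units; beyond the scatter) in this assay, which is the first direct sign that a large group here matters. The value for compound 3 is a limit of the assay, not a number: the limit of > 100000 nM in this assay, at which 1 of the 4 values shown sits.

The compounds shown leave open whether methyl, an amine or a carboxylic acid on this carbon would also give a measurable number. They also do not show why phenyl has this effect.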